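From chloro to cyano on compound 1

This account rests on a few compounds, and the source may have more. Where it says the series, first, only, none or still open, it means among the compounds named here.

Two compounds have numbers so far in an in vitro ADME assay on microsomes from liver (Homo sapiens) for metabolic stability (a lower number here means slower removal, a higher number faster removal of the compound), as follows:
- compound 1 `O=C(Nc1cccnc1-c1cccc(Cl)c1)N1CCN2C(=O)N([C@H]3C[C@@H]3c3ccccc3)C(=O)[C@@H]2C1` gives 90000 mL.min-1.g-1 as its reading
- compound 2 `O=C(Nc1ccnn1-c1cccc(F)c1)N1CCN2C(=O)N([C@H]3C[C@@H]3c3ccccc3)C(=O)[C@@H]2C1` gives 45000 mL.min-1.g-1 as its reading

On these numbers, compound 1 stands level with compound 2. The gap between them lies within the usual scatter of repeated measurements, so the two cannot be ranked.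

The next compound is compound 3 `N#Cc1cccc(-c2ncccc2NC(=O)N2CCN3C(=O)N([C@H]4C[C@@H]4c4ccccc4)C(=O)[C@@H]3C2)c1`, which keeps all of compound 1 except for one group. The change reads cyano in place of chloro on an aromatic carbon and in words it is cyano in place of chloro on an aromatic carbon, so 3-chlorophenyl becomes 3-cyanophenyl.

Among the compounds with values here, no measured pair of compounds differs in this one place alone, so the data say nothing direct about this swap. Within the data shown here, the only guide is the general level: compound 1 at 90000 mL.min-1.g-1 and compound 2 at 45000 mL.min-1.g-1 lie within the scatter of each other, although they differ in more than one place. The estimated 1.5-fold lower number from compound 1 to compound 3 (0.18 log units; within the scatter) in this assay is therefore expected to be slightly downward and to stay within the scatter. For compound 3 the expected value is 60000 mL.min-1.g-1 with an estimated range from 25000 mL.min-1.g-1 to 120000 mL.min-1.g-1 around it.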

Compound 3, intrinsic clearance in microsomes: 37000 mL.min-1.g-1
The estimate for compound 3 lay 1.6-fold (0.21 log units) above the measured number; measured number inside the range.
By their numbers in this assay, from the lowest: compounds 3, 2 and 1 (each within the scatter of the next, the first and the last beyond it).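

Within the data shown here, compound 1 and compound 3 form the first pair here that differs in one place alone, so the change from 3-chlorophenyl to 3-cyanophenyl can now be read directly rather than inferred from the general level of the series. The swap brings a 2.4-fold lower number from compound 1 to compound 3 (0.39 log units; beyond the scatter) in this assay and, although modest, this step lies beyond the usual scatter, so the group on this aromatic carbon does affect the number and a change here can be told apart from repeat-to-repeat noise. Nothing available explains why the number moves in this direction.

As far as these compounds go, it remains open whether the step is particular to cyano, or whether a methyl, a methoxy, a trifluoromethyl or a carboxylic acid on the same carbon would give a similar, larger or opposite step. Among these compounds, also open is whether the same swap would give a comparable step on compound 2, and whether any group at this place could carry the number much further down, since a single pair shows only one change in one setting.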